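Adding a nitro group to compound 2

The compounds below may be only part of what the source reports. "The series", "measured", "known", "first", "only" and "open" are said of these compounds alone.

Among the compounds with values here, in a functional assay on MCF7 cells (Homo sapiens) for antiproliferative activity, read by MTT assay, with a stated time of 48 h (a lower number here means a stronger inhibitor, a higher number a weaker inhibitor), compound 2 `N=C(N)N/N=C(/C=C/c1ccccc1)c1ccccc1` gives 17000 nM, the highest of the two numbers measured so far, which makes it the weaker inhibitor of the pair. The other measured compound, compound 1 `N=C(N)N/N=C(/C=C/c1ccc(F)cc1)c1ccccc1`, carries a fluoro group and gives 2500 nM in the same test.

The next compound, compound 3 `N=C(N)N/N=C(/C=C/c1cccc([N+](=O)[O-])c1)c1ccccc1`, is built from compound 2 by placing nitro in place of hydrogen on an aromatic carbon, meta to a large group (nitro in place of hydrogen on an aromatic carbon). Within the data shown here, only one measured step bears on this change. It is the swap of fluoro for hydrogen, with a 6.8-fold higher number from compound 1 to compound 2 (0.83 log units; beyond the scatter) as its size. Read backwards, that step shows a group replacing hydrogen on an aromatic carbon alongside a lower number. It is a modest step, it involves a different group, and it is a single example, so it offers only a loose guide.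

A smaller move in the same direction is therefore expected, with a 2.8-fold lower number from compound 2 to compound 3 (0.45 log units; beyond the scatter) as the estimated step in this assay for now. The estimate for compound 3 is 6000 nM (expected range 1800 nM to 20000 nM).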

Compound 3, half-maximal inhibitory concentration: 6500 nM
For compound 3 the middle estimate is 1.1-fold (0.03 log units) below the measured one; measured number inside the range.
By their numbers in this assay, from the lowest: compound 1; then compound 3; then compound 2.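

In this assay, within the data shown here, placing a nitro group on an aromatic carbon, meta to a large group, gives a 2.6-fold lower number from compound 2 to compound 3 (0.42 log units; beyond the scatter) and so provides the first direct reading for this group at this place. The other measured step gives a 6.8-fold higher number from compound 1 to compound 2 (0.83 log units; beyond the scatter), and there hydrogen enters instead of leaving. Together, the two steps mean that two different groups, fluoro and nitro, now each go with a lower number than hydrogen on an aromatic carbon, and no compound shown goes against this small pattern. Nothing available explains why the number falls when nitro replaces hydrogen.

Among these compounds, the nitro group is seen at only one place on the ring, so it remains open whether the lower number belongs to that place or would also appear with nitro elsewhere on the ring. The compounds shown also leave open how an amine or a carboxylic acid on the same aromatic carbon would compare, and therefore whether this modest gain extends to groups beyond fluoro and nitro.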